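A few compounds are considered here, and "the series" means these few. Any claim that something is new, unique, unknown or untested is made for them only; others in the source may bear on it.

Of the compounds shown here, three have so far been tested in a functional assay on MCF7 cells (Homo sapiens) for inhibition, read by MTT assay, with a stated time of 72 h; a lower number here means a stronger inhibitor, a higher number a weaker inhibitor. Compound 1 `Cc1cc(Nc2cc(-c3ccccc3)[nH]n2)n2nc(SCc3cccc(Br)c3)nc2n1` gives 5140 nM there. Compound 2 `Cc1cc(Nc2ccn(Cc3nc(C)c4ccccc4n3)n2)n2nc(SCc3ccc(Br)cc3)nc2n1` gives 1430 nM, and compound 3 `Cc1nc2nc(SCc3ccc(Cl)cc3)nn2c(Nc2cc(-c3ccccc3)[nH]n2)c1C` gives 10600 nM. Compound 1 thus stands second highest of the three: its nearest neighbour is compound 3, which sits higher, and its furthest is compound 2, which sits lower, with both gaps beyond the usual scatter of repeated measurements. Compound 4 `Cc1cc(Nc2cc(-c3ccccc3)[nH]n2)n2nc(SCc3ccc(Br)cc3)nc2n1` has not yet been measured. It differs from compound 1 in a single place: 4-bromophenyl in place of 3-bromophenyl on a saturated chain carbon bound to a sulfur. Going by the values given here, no measured pair differs in this way alone, so the size of the step cannot be read from the data. Compound 4 is expected to come in near 4000 nM, within 1500 nM to 10000 nM. The expected step of a 1.3-fold lower number from compound 1 to compound 4 (0.11 log units; within the scatter) is small, in either direction, and probably not beyond the scatter.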

Compound 4, half-maximal inhibitory concentration: 2720 nM
Beside the measured number, compound 4's estimate is 1.5-fold (0.17 log units) above it; the range from low to high includes it.
By their numbers in this assay, from the lowest: compounds 2, 4 and 1 (each within the scatter of the next, the first and the last beyond it); then compound 3.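

In this assay, putting 4-bromophenyl in place of 3-bromophenyl on a saturated chain carbon bound to a sulfur gives a 1.9-fold lower number from compound 1 to compound 4 (0.28 log units; within the scatter) and so leaves the two compounds indistinguishable. Going by these compounds alone, this is the first direct reading at this place, and it shows that this shift of the bromine has no effect that can be told from the usual scatter. Nothing measured here speaks to the reason for this result. Still open, on these data alone, is whether a different group on the ring at this place, such as a methoxy group or a carboxylic acid, would give a step beyond the scatter.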